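The compounds below may be only part of what the source reports. "The series", "measured", "known", "first", "only" and "open" are said of these compounds alone.

Compound 1, `COc1ccnc(N2CCC(NC(=S)Nc3cccnc3)CC2)c1`, gives > 5000 nM in an assay on membranes from brain for binding affinity to Lysophosphatidylserine lipase ABHD12 (Mus musculus), read by fluorescence, with a stated time of 20 min (on this read-out higher numbers stand for weaker inhibition and lower numbers for stronger inhibition), which is a limit of the assay rather than a number.
Compound 2, `S=C(Nc1cccnc1)NC1CCN(c2cc(OC3CCCCC3)ccn2)CC1`, gives 3400 nM in this assay.

Among the compounds with values here, compound 2 thus holds the only number reported in this assay; the single other value is a limit. Within the data shown here, the one measured step, an at least 1.4-fold lower number from compound 1 to compound 2 (0.16 log units; that floor lies within the scatter), is the only evidence bearing on the change to compound 3, and its floor lies within the scatter, so it vouches for no step of any size. Compound 3, `S=C(Nc1cccnc1)NC1CCN(c2cc(OCC3CC3)ccn2)CC1`, differs from compound 2 by cyclopropylmethyl in place of cyclohexyl on an oxygen on an aromatic ring. In the heavy atoms counted, the entering cyclopropylmethyl sits between the methyl of compound 1 and the cyclohexyl of compound 2. Since the change from methyl to cyclohexyl could not be sized beyond the scatter, the step of a 1.2-fold higher number from compound 2 to compound 3 (0.07 log units; within the scatter) is expected to stay within the scatter as well. Compound 3 is therefore estimated at 4000 nM, with a range from 1500 nM to 12000 nM, and a fair chance that the assay again returns only a limit.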

Compound 3, half-maximal inhibitory concentration: 4700 nM
Compound 3: middle estimate off by 1.2-fold (0.07 log units), on the low side; measured number inside the range.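

Replacing cyclohexyl with cyclopropylmethyl on an oxygen on an aromatic ring gives a 1.4-fold higher number from compound 2 to compound 3 (0.14 log units; within the scatter), so in this assay the two groups cannot be told apart at this position, despite their different ring sizes and heavy-atom counts. Cyclopropyl in place of hydrogen on the saturated chain carbon bound to that oxygen gives an at least 1.0-fold lower number from compound 1 to compound 3 (0.02 log units; that floor lies within the scatter), which shows no gain beyond the scatter from this addition. The true size of that step cannot be read, because one end of it is a limit of the assay and not a number: the limit of > 5000 nM in this assay, at which 1 of the 3 values shown sits.

On these data alone, what a benzyl group, a longer chain or a chain ending in an amine would do on this oxygen stays open. So does whether any replacement at this place can move the number beyond the scatter.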